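Swapping an aromatic ring for piperidine on a long chain

The source may hold more compounds than are shown below. What is called first, only, known or untested is meant among the compounds shown, and "the series" means these compounds.

compound 1 | `COc1ccc([C@H](O)COCCOC[C@H](O)C#CCCCCCCC[C@@H]2CC(CC(C)=O)C(=O)O2)cc1` | > 10000 nM
compound 2 | `CCCCN(CCCC)C(O)(O)COCCOCC(O)(O)C#CCCCCCCC[C@@H]1CC(CC(C)=O)C(=O)O1` | 3900 nM
compound 3 | `CCCCCCCCN(CCCCCCCC)C(O)(O)COCCOCC(O)(O)C#CCCCCCCC[C@@H]1CC(CC(C)=O)C(=O)O1` | 3700 nM

All three compounds were tested in a functional assay on L1210 cells (Mus musculus) for inhibition (a lower number here means a stronger inhibitor, a higher number a weaker inhibitor), and share a long chain on the same kind of core. For compound 1 the reading > 10000 nM is a limit of the assay and not a number. Compound 1 thus stands at the limit of > 10000 nM in this assay, at which 1 of the 3 values shown sits, and has no exact place on the scale. Compound 2 gives 3900 nM and compound 3 gives 3700 nM as true numbers, and these lie within the usual scatter of each other.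

Compound 4 (`CC(=O)CC1C[C@@H](CCCCCCCC#C[C@@H](O)COCCOC[C@@H](O)N2CCCCC2)OC1=O`) has not been measured yet. Its difference from compound 1 is this: piperidin-1-yl in place of 4-methoxyphenyl on a saturated chain carbon bound to an oxygen on a saturated carbon and a saturated chain carbon (in words, piperidin-1-yl in place of 4-methoxyphenyl). Within the data shown here, no measured pair shows this change alone, so any forecast is loose. Compound 2 at 3900 nM and compound 3 at 3700 nM both contain nitrogen, as compound 4 does, and that suggests a modest move towards stronger inhibition in this assay rather than a large one. The expected change is an at least 2.0-fold lower number from compound 1 to compound 4 (0.30 log units; that floor lies within the scatter) as a rough estimate. For compound 4 the expected value is 5000 nM within an estimated range of 1800 nM to 12000 nM as a cautious expectation.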

Compound 4, half-maximal inhibitory concentration: 28700 nM
Compound 4: the middle estimate sits 5.7-fold (0.76 log units) below what was measured, outside the stated range (above it).
By their numbers in this assay, from the lowest: compounds 3 and 2 (each within the scatter of the next); then compound 4.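

Among these compounds, no step from compound 1 to compound 4 can be read, because compound 1 has only a limit of the assay and not a true number: the limit of > 10000 nM in this assay, at which 1 of the 4 values shown sits. The compounds shown leave open how far, and even in which direction, piperidin-1-yl in place of 4-methoxyphenyl moves the result in this assay.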